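The source may hold more compounds than are shown below. What is called first, only, known or untested is meant among the compounds shown, and "the series" means these compounds.

Measured in an ADME assay on LLC-MK2 cells (Macaca mulatta) for cytotoxicity, read by MTT assay, with a stated time of 48 h; on this read-out higher numbers stand for lower toxicity in this test and lower numbers for higher toxicity in this test:
- Compound 1 `C/C(=C\c1ccccc1)C(=O)/C=C/c1ccccc1`: 33600 nM
- Compound 2 `COc1ccc(/C=C/C(=O)/C(C)=C/c2ccccc2)cc1`: 93000 nM
- Compound 3 `C/C(=C\c1ccccc1)C(=O)/C=C/c1ccc([N+](=O)[O-])cc1`: 43300 nM

Compound 1 stands at the low end of these numbers, and its nearest neighbour shows a 1.3-fold higher number from compound 1 to compound 3 (0.11 log units; within the scatter). Compound 4 `COc1ccc(/C=C(\C)C(=O)/C=C/c2ccccc2)cc1` has not yet been measured. Its change is methoxy in place of hydrogen on an aromatic carbon, para to a large group. Among the measured compounds shown here, the closest precedent is compound 2, which has methoxy on a different aromatic ring and shows a 2.8-fold higher number from compound 1 to compound 2 (0.44 log units; beyond the scatter), a modest step. The nitro step, a 1.3-fold higher number from compound 1 to compound 3 (0.11 log units; within the scatter), bears on it less directly. A similar modest rise is therefore expected in this assay. The expected step is a 1.9-fold higher number from compound 1 to compound 4 (0.29 log units; within the scatter). Compound 4 is estimated at 65000 nM, with an expected range of 33000 nM to 125000 nM.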

Compound 4, half-maximal cytotoxic concentration: 44000 nM
Compound 4: the middle estimate sits 1.5-fold (0.17 log units) above what was measured; low and high end bracket the measured number.
By their numbers in this assay, from the lowest: compounds 1, 3 and 4 (each within the scatter of the next); then compound 2.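

In this assay, among the compounds shown here, methoxy in place of hydrogen on an aromatic carbon, para to a large group, gives a 1.3-fold higher number from compound 1 to compound 4 (0.12 log units; within the scatter) while the same exchange on the other aromatic ring gives a 2.8-fold higher number from compound 1 to compound 2 (0.44 log units; beyond the scatter) and only that second step lies beyond the scatter. The same group therefore does not give the same kind of step on both rings of the core of compound 1. No measurement shown here explains this difference. Still open, on these data alone, is whether an amine or a carboxylic acid at this position would move the number beyond the scatter. Also open, as far as these compounds go, is what methoxy on both rings together would give.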